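A few compounds are considered here, and "the series" means these few. Any claim that something is new, unique, unknown or untested is made for them only; others in the source may bear on it.

Compound 2 `Cc1nc(S(C)(=O)=O)ccc1Oc1ncnc(OC2CCN(C(=O)C(F)(F)F)CC2)c1F` sits lowest of the two numbers in a functional assay on isolated protein for inhibition of Glucose-dependent insulinotropic receptor (Rattus norvegicus), read by HTRF and cAMP accumulation; a higher number here means a larger maximal response, a lower number a smaller maximal response; there compound 2 gives 76%, and its nearest neighbour compound 1 `Cc1nc(S(C)(=O)=O)ccc1Oc1ncnc(OC2CCN(C(=O)O[C@H](C)C(F)(F)F)CC2)c1F` gives 85%, the two lying within the scatter. Within the data shown here, the only step measured so far, a number 9 percentage points lower from compound 1 to compound 2 (within the scatter), also touched the group on the carbonyl carbon. Compound 3 `Cc1nc(S(C)(=O)=O)ccc1Oc1ncnc(OC2CCN(C(=O)C(C)(F)F)CC2)c1F` differs from compound 2 by methyl in place of fluoro on a saturated chain carbon bound to a carbonyl carbon and two fluorine atoms. Since that neighbouring step stayed within the scatter, compound 3 is expected to show no change beyond it, a step of a number 2 percentage points higher from compound 2 to compound 3 (within the scatter). The estimate for compound 3 in this assay is 78%, within 64% to 92%.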

Compound 3, largest response reached (reported as efficacy), in percent of the reference or control that the assay uses: 87%
For compound 3 the middle estimate is 9 percentage points below the measured one, and the stated range covers the measured number.
By their numbers in this assay, from the lowest: compounds 2, 1 and 3 (each within the scatter of the next, the first and the last beyond it).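

In this assay, methyl in place of fluoro on this saturated chain carbon gives a number 11 percentage points higher from compound 2 to compound 3 (beyond the scatter) and so, unlike the earlier change at this carbonyl carbon, moves the response beyond the scatter, if only modestly. The 1,1-difluoroethyl and 1-(trifluoromethyl)ethoxy groups on the carbonyl carbon cannot be told apart, with a number 2 percentage points higher from compound 1 to compound 3 (within the scatter) in this comparison. Nothing available here accounts for the step.

Going by these compounds, whether the response changes further with an isopropyl or cyclopropyl group on the carbonyl carbon remains open. So does the effect of an ethyl group there, with no fluorine atoms on the chain.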